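The source may report more compounds than this note shows. Statements on the series, on what has been measured and on what is new or still open speak of the compounds shown alone.

Working notes on the series. Three compounds carry a number in a functional assay on KB cells (Homo sapiens) for cytotoxicity, read by sulforhodamine B assay; a higher number here means a weaker inhibitor, a lower number a stronger inhibitor. Compound 1 `C=C1[C@@H](OC(C)=O)C[C@@H]2[C@](C)(CO[Si](C)(C)C(C)(C)C)[C@H](OC(C)=O)CC[C@@]2(C)[C@@H]1C[C@@H](Nc1ccc(Br)cc1)C1=CCOC1=O` gives 5230 nM in this assay. Compound 2 `C=C1[C@@H](OC(C)=O)C[C@@H]2[C@](C)(COC=O)[C@H](OC(C)=O)CC[C@@]2(C)[C@@H]1C[C@@H](Nc1ccc(Br)cc1)C1=CCOC1=O` gives 24000 nM in this assay. Compound 3 `C=C1[C@@H](OC(C)=O)C[C@@H]2[C@](C)(COC=O)[C@H](OC(C)=O)CC[C@@]2(C)[C@@H]1C[C@@H](Nc1cccc2ccccc12)C1=CCOC1=O` gives 32300 nM in this assay. Compound 1 stands lowest of the three numbers; the nearest to it is compound 2, the furthest compound 3, and both gaps lie beyond the scatter.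

Two single-point steps are known. Putting a group of 2 heavy atoms in place of a group of 7 heavy atoms on the oxygen on a saturated carbon gives a 4.6-fold higher number from compound 1 to compound 2 (0.66 log units; beyond the scatter). Putting naphthalen-1-yl in place of 4-bromophenyl on the amine nitrogen gives a 1.3-fold higher number from compound 2 to compound 3 (0.13 log units; within the scatter), which does not rise above the scatter.

Compound 4 `C=C1[C@@H](OC(C)=O)C[C@@H]2[C@](C)(CO[Si](C)(C)C(C)(C)C)[C@H](OC(C)=O)CC[C@@]2(C)[C@@H]1C[C@@H](Nc1cccc(OC)c1)C1=CCOC1=O` has no number yet. It differs from compound 1 in one place: 3-methoxyphenyl in place of 4-bromophenyl on an amine nitrogen. Only the second known step bears on this, since it also exchanges the aryl on the amine nitrogen, and that exchange stayed within the scatter. No step beyond the scatter is therefore expected in this assay, with a slight lean towards a higher number. Compound 4 is expected to give 7000 nM in this assay, within a range from 2500 nM to 20000 nM. This amounts to an expected 1.3-fold higher number from compound 1 to compound 4 (0.13 log units; within the scatter).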

Compound 4, half-maximal inhibitory concentration: 45200 nM
For compound 4 the middle estimate is 6.5-fold (0.81 log units) below the measured one; measured number outside the range, above it.
By their numbers in this assay, from the lowest: compound 1; then compounds 2, 3 and 4 (each within the scatter of the next).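

In this assay, the aryl on the amine nitrogen is not a silent position: 3-methoxyphenyl in place of 4-bromophenyl gives an 8.6-fold higher number from compound 1 to compound 4 (0.94 log units; beyond the scatter), whereas the earlier exchange at the same nitrogen, naphthalen-1-yl in place of 4-bromophenyl, gave only a 1.3-fold higher number from compound 2 to compound 3 (0.13 log units; within the scatter), on a background carrying the smaller group on the oxygen. The low number of compound 1 therefore depends on both places, since the change on the oxygen, at a 4.6-fold higher number from compound 1 to compound 2 (0.66 log units; beyond the scatter), and the change on the nitrogen each move the number up beyond the scatter. No measurement at hand explains why the 3-methoxyphenyl exchange costs so much, or why the two aryl exchanges differ in size.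

Going by these compounds, the two exchanges differ in the aryl group and in the group on the oxygen, so it stays open whether the response at the nitrogen depends on that oxygen substituent, which naphthalen-1-yl paired with the silicon-bearing group would address. On these data alone, it also stays open whether the loss follows from removing the bromine or from introducing the methoxy group, a question that plain phenyl on the amine nitrogen would help to settle.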